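Methylation of the phenol in the urea series

The source may report more compounds than this note shows. Statements on the series, on what has been measured and on what is new or still open speak of the compounds shown alone.

Compound 2 `O=C(Nc1cccc(-n2cc(-c3ccncc3)c(-c3cc(O)cc(Cl)c3)n2)c1)Nc1ccc(Cl)c(C(F)(F)F)c1` gives 63.1% in a functional assay on SK-OV-3 cells (Homo sapiens) for inhibition, read by sulforhodamine B assay, with a stated time of 48 h, tested at 10 uM (a higher number here means a weaker effect of the compound at the concentration tested, a lower number a stronger effect), standing second highest of the three numbers. Compound 1 `COc1cc(Cl)cc(-c2nn(-c3cccc(NC(=O)c4ccc(Cl)c(Cl)c4)c3)cc2-c2ccncc2)c1` gives 80.1% and compound 3 `O=C(Nc1cccc(-n2cc(-c3ccncc3)c(-c3cc(O)cc(Cl)c3)n2)c1)Nc1ccc(Cl)c(Cl)c1` gives 13.2%. Both of these differ from compound 2 by more than the usual scatter. Among the measured compounds shown here, the one measured step, a number 49.9 percentage points lower from compound 2 to compound 3 (beyond the scatter), concerns a different site. Compound 4 `COc1cc(Cl)cc(-c2nn(-c3cccc(NC(=O)Nc4ccc(Cl)c(C(F)(F)F)c4)c3)cc2-c2ccncc2)c1` differs from compound 2 by methyl in place of hydrogen on an oxygen on an aromatic ring. For the measured compounds named here, no measured pair isolates this change; compound 1 carries methoxy but also an amide in place of the urea, so only its value can be compared. Compound 4 is therefore expected to stay close to compound 2, an estimated a number 4.9 percentage points higher from compound 2 to compound 4 (within the scatter) in this assay, within the scatter. The expected value for compound 4 is 68%, range 45% to 90%.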

Compound 4, a percentage reported as activity, at one concentration (the size of the read-out at that concentration, not a potency): 12%
The estimate for compound 4 lay 56 percentage points above the measured number; the measured number lies below the stated range.
By their numbers in this assay, from the lowest: compounds 4 and 3 (each within the scatter of the next); then compound 2; then compound 1.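

Hydroxy to methoxy on the 3-chloro-5-hydroxyphenyl group gives a number 51.1 percentage points lower from compound 2 to compound 4 (beyond the scatter) in this assay, so this oxygen is a sensitive site in the urea series. Methoxy alone does not set the outcome: (4-chloro-3-(trifluoromethyl)phenyl)amino in place of 3,4-dichlorophenyl on the carbonyl carbon gives a number 68.1 percentage points lower from compound 1 to compound 4 (beyond the scatter) with methoxy present in both compounds. Nothing available explains either step.

Open, as far as these compounds go, is whether ethoxy, a longer chain or an amine at this position would hold the low number. Also open, from the compounds shown here alone, is how methoxy behaves alongside the 3,4-dichlorophenyl urea of compound 3.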